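The compounds below may be only part of what the source reports. "The series", "measured", "known", "first", "only" and "open" are said of these compounds alone.

Measured compounds in an assay on MDA-MB-231 cells for binding affinity to C-X-C chemokine receptor type 4 (Homo sapiens), read by immunofluorescence and microscopy, with stated times of 10 min and 30 min; a lower number here means that less compound is needed, a higher number that more compound is needed for the effect:
compound 1 `Cc1ccc(S(=O)(=O)NCc2ccc(CNC(=O)c3ccc(F)cc3)cc2)cc1` gives 1 nM;
compound 2 `COc1ccc(C(=O)NCc2ccc(CNS(=O)(=O)c3ccccc3)cc2)cc1` gives 1000 nM;
compound 3 `Cc1ccc(S(=O)(=O)NCc2ccc(CNC(=O)c3ccccc3Cl)cc2)cc1` gives 10 nM.

Compound 2 stands at the top of this set: its number is far beyond the scatter from compound 3 and further still from compound 1. The step to compound 4 `Cc1ccccc1C(=O)NCc1ccc(CNS(=O)(=O)c2ccccc2)cc1` changes the group on the carbonyl carbon: 2-methylphenyl in place of 4-methoxyphenyl on a carbonyl carbon. Among the measured compounds shown here, the only measured step that resembles this, a 10-fold higher number from compound 1 to compound 3 (1.00 log units; beyond the scatter), moved the number upward, but it concerns other groups on a different core, so it bears on the present step only loosely. For the measured compounds named here, compound 2 already sits high, and the single step gives no firm direction, so for compound 4 a step of about no change at the digits printed from compound 2 to compound 4 (within the scatter) in this assay is expected, within the scatter. Compound 4 is therefore estimated at 1000 nM, between 250 nM and 4000 nM.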

Compound 4, effective concentration (reported as EC, without a stated level of effect): 1 nM
Compound 4: the middle estimate sits 1000-fold (3.00 log units) above what was measured; the measured number lies below the stated range.
By their numbers in this assay, from the lowest: compounds 1 and 4 (each within the scatter of the next); then compound 3; then compound 2.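

On a carbonyl carbon whose other neighbour is an amide-type nitrogen, 2-methylphenyl in place of 4-methoxyphenyl gives a 1000-fold lower number from compound 2 to compound 4 (3.00 log units; beyond the scatter) in this assay. This single change therefore spans the full range of numbers shown so far, on a core where no step had been seen before. No measured evidence accounts for the size of this step.

The compounds shown do not separate the loss of the methoxy group from the gain of the methyl group. From the compounds shown here alone, how a carboxylic acid or an amine would read in this place also remains open.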